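Cyclohexyloxy replacing oxan-4-yl in a beta-lactam carbamate

The compounds below may be only part of what the source reports. "The series", "measured", "known", "first", "only" and "open" are said of these compounds alone.

Measured so far:
compound 1, `CCCCc1ccc(COC(=O)N[C@H]2CNC2=O)cc1`: 23 nM
compound 2, `O=C(N[C@H]1CNC1=O)OCc1ccc(C2CCOCC2)cc1`: 1370 nM

In an assay on HEK293 cells for inhibition of N-acylethanolamine-hydrolyzing acid amidase (Homo sapiens), read by fluorescence, with stated times of 10 min and 50 min (a higher number here means a weaker inhibitor, a lower number a stronger inhibitor), compound 2 gives the higher of the two numbers, standing a 60-fold higher number from compound 1 to compound 2 (1.77 log units; beyond the scatter) away from compound 1. The step now taken is from compound 2 to compound 3, `O=C(N[C@H]1CNC1=O)OCc1ccc(OC2CCCCC2)cc1`, where (cyclohexyloxy in place of oxan-4-yl on an aromatic carbon). For the measured compounds named here, the single known step, a 60-fold higher number from compound 1 to compound 2 (1.77 log units; beyond the scatter), shows that swapping a butyl for a ring carrying an oxygen changed this assay greatly; the present change removes that oxygen from the ring and places one between the ring and the aromatic carbon. Going by the values given here, no measured pair covers exactly this, so the direction is uncertain, but a moderate move toward the value of compound 1 is expected, a 9.1-fold lower number from compound 2 to compound 3 (0.96 log units; beyond the scatter). Compound 3 is estimated at 150 nM, within 25 nM to 900 nM.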

Compound 3, half-maximal inhibitory concentration: 2070 nM
Beside the measured number, compound 3's estimate is 14-fold (1.14 log units) below it; the measured number lies above the stated range.
By their numbers in this assay, from the lowest: compound 1; then compounds 2 and 3 (each within the scatter of the next).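

Cyclohexyloxy in place of oxan-4-yl gives a 1.5-fold higher number from compound 2 to compound 3 (0.18 log units; within the scatter) in this assay and so leaves the two groups indistinguishable on this aromatic carbon. Cyclohexyloxy in place of butyl gives a 90-fold higher number from compound 1 to compound 3 (1.95 log units; beyond the scatter) and shows that a six-membered non-aromatic ring of carbon only, attached through oxygen, also falls far short of butyl here. No measurement available explains this result. Still open, on these data alone, is whether a longer chain such as hexyl, or a smaller ring such as cyclopropyl, would match butyl at this place.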